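The source may report more compounds than this note shows. Statements on the series, on what has been measured and on what is new or still open speak of the compounds shown alone.

Working notes on the series. The shared core of compound 1 `CN(C)CCn1cnnc1-c1cc(Oc2ccc(NC(=O)N/N=C/c3c(Cl)cccc3Cl)cc2F)ccn1` carries an acylhydrazone whose aryl part is varied. In a functional assay on HT-29 cells (Homo sapiens) for cytotoxicity, read by MTT assay, with a stated time of 72 h (on this read-out lower numbers stand for stronger inhibition and higher numbers for weaker inhibition), compound 1 gives 280 nM. Compound 2 `CN(C)CCn1cnnc1-c1cc(Oc2ccc(NC(=O)N/N=C/c3ccc(O)c(Br)c3)cc2F)ccn1` differs only in that aryl part, and in this assay compound 2 gives 450 nM. For the measured compounds named here, the one step so far, a 1.6-fold higher number from compound 1 to compound 2 (0.21 log units; within the scatter), sits inside the scatter of repeated runs; compound 2 thus stands at the upper end of the two numbers, but not separated from compound 1 beyond the scatter.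

Compound 3 `CN(C)CCn1cnnc1-c1cc(Oc2ccc(NC(=O)N/N=C/c3ccc(F)cc3)cc2F)ccn1` continues along the same position: 4-fluorophenyl in place of 3-bromo-4-hydroxyphenyl on a carbon with a double bond to nitrogen. Going by the values given here, the only step that bears on this change is the aryl swap a 1.6-fold higher number from compound 1 to compound 2 (0.21 log units; within the scatter), which did not move the number beyond the scatter, so a further aryl swap at the same carbon is expected to leave this assay essentially unchanged, with the step of a 1.3-fold lower number from compound 2 to compound 3 (0.11 log units; within the scatter) expected to fall within the scatter, in no particular direction. Among the compounds with values here, with only one prior aryl step to draw on, the range is kept wide. Compound 3 is estimated at 350 nM in this assay, with a range from 150 nM to 900 nM.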

Compound 3, half-maximal inhibitory concentration: 1370 nM
Beside the measured number, compound 3's estimate is 3.9-fold (0.59 log units) below it; the measured number lies above the stated range.
By their numbers in this assay, from the lowest: compounds 1 and 2 (each within the scatter of the next); then compound 3.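

This position is not indifferent to the aryl group after all: in this assay the change to 4-fluorophenyl gives a 3.0-fold higher number from compound 2 to compound 3 (0.48 log units; beyond the scatter), and the same group gives a 4.9-fold higher number from compound 1 to compound 3 (0.69 log units; beyond the scatter), so it separates from both 3-bromo-4-hydroxyphenyl and 2,6-dichlorophenyl, which remain within the scatter of each other. Loss of the hydroxyl cannot be the whole story on these numbers, since compound 1 carries no hydroxyl and still stays with compound 2, apart from compound 3. Nothing available gives a reason for this separation.

Open, on these data alone, is whether a plain phenyl, 4-chlorophenyl or 4-hydroxyphenyl without the bromine would fall with compound 1 and compound 2 or with compound 3, which would show whether the 4-fluoro substituent itself or the absence of further ring substituents goes with the higher number. Also open, as far as these compounds go, is how far this carbon tolerates other kinds of group, such as a phenyl ring carrying an amine or a carboxylic acid, or a saturated ring in place of the aryl group.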